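Swapping Cyclohexylmethyl for 2-Methoxyphenoxy: Acid Dissociation Outlook

This account rests on a few compounds, and the source may have more. Where it says the series, first, only, none or still open, it means among the compounds named here.

Measured compounds in a physicochemical assay for acid dissociation:
compound 1 `COc1ccc(F)cc1CNCCCNc1ccnc2cc(CC(C)C)ccc12` gives 9.47
compound 2 `CCC(CC)c1ccc2c(NCCCNCc3cc(F)ccc3OC)ccnc2c1` gives 9.47
compound 3 `COc1ccc(F)cc1CNCCCNc1ccnc2cc(CC3CCCCC3)ccc12` gives 9.47

Compound 3 stands level with compounds 1 and 2 in this assay; the step of no change at the digits printed from compound 1 to compound 3 (within the scatter) and the step of no change at the digits printed from compound 2 to compound 3 (within the scatter) both lie within the scatter, as does the step of no change at the digits printed from compound 1 to compound 2 (within the scatter) between the other two. Across these three compounds the group on the aromatic carbon of the shared core has been varied without any movement in the read-out.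

Compound 4 `COc1ccc(F)cc1CNCCCNc1ccnc2cc(Oc3ccccc3OC)ccc12` is the next member. Its difference from compound 3 is 2-methoxyphenoxy in place of cyclohexylmethyl on an aromatic carbon.

The three measured steps all concern the same position and all showed no change beyond the scatter, so they bear directly on this step. The entering group is, however, of a different kind from those tried so far, so the measured steps do not cover it exactly. Still, on the evidence at hand the expected step of a number 0.07 log units lower from compound 3 to compound 4 (within the scatter) is none beyond the scatter. Compound 4 is therefore estimated at 9.4, with a range from 9 to 9.8.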

Compound 4, acid dissociation constant: 9.28
For compound 4 the middle estimate is 0.12 log units above the measured one, within the range that was stated.
By their numbers in this assay, from the lowest: compounds 4, 1, 2 and 3 (each within the scatter of the next).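

In this assay, among these compounds, the earlier compounds carried only all-carbon groups on this aromatic carbon, whereas 2-methoxyphenoxy places an aromatic ring and oxygen there, and the read-out still does not move beyond the scatter: the steps are a number 0.19 log units lower from compound 3 to compound 4 (within the scatter) and a number 0.19 log units lower from compound 2 to compound 4 (within the scatter) and also a number 0.19 log units lower from compound 1 to compound 4 (within the scatter). Among the compounds shown here, compound 4 is the first compound here whose digits are not identical to the others, but none of its three steps can be read as a real shift, so a change in the kind of group, and not only in the shape of an all-carbon group, has so far left this read-out within the scatter. The information at hand offers no explanation for the difference in the digits.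

On these data alone, whether a carboxylic acid, a primary amine or a nitrile on this aromatic carbon would move the read-out beyond the scatter remains open, as does the share of the methoxy group in this result, which a plain phenoxy group could address. All four compounds share the rest of the structure, so these steps do not tell how the same swap would read with a different group elsewhere.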